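The source may report more compounds than this note shows. Statements on the series, on what has been measured and on what is new or still open speak of the compounds shown alone.

Measured compounds:
compound 1, `CCC/C=C/C(=O)N(Cc1ccc(OC)c(O)c1)c1cc(OC)c(OC)c(OC)c1`, 70 nM
compound 2, `COc1ccc(CNc2cc(OC)c(OC)c(OC)c2)cc1Br`, 29400 nM
compound 3, `COC(=O)c1cc(CNc2cc(OC)c(OC)c(OC)c2)ccc1OC`, 49600 nM

In a functional assay on MGC-803 cells (Homo sapiens) for inhibition, read by MTT assay, with a stated time of 48 h (on this read-out lower numbers stand for stronger inhibition and higher numbers for weaker inhibition), compound 1 gives the lowest of the three numbers. Going by the values given here, compound 2 sits a long way from it, and compound 3 further still; the one measured step, a 1.7-fold higher number from compound 2 to compound 3 (0.23 log units; within the scatter), lies within the scatter, so those two compounds cannot be set apart. Both of them lack the carbonyl on the nitrogen altogether, while compound 1 carries it.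

The unmeasured compound 4, `COc1ccc(CN(C(C)=O)c2cc(OC)c(OC)c(OC)c2)cc1O`, keeps that carbonyl and the core of compound 1 but shortens the group on it:

methyl in place of pent-1-en-1-yl on a carbonyl carbon

Cut one bond further out, this is (pent-1-en-1-yl)carbonyl to acetyl. Among the compounds with values here, no measured step touches this carbonyl or the chain on it; the only step available, from compound 2 to compound 3, concerns a different position and is within the scatter. The gap between compound 1 and the two compounds without the carbonyl shows that much of the activity is tied to that part of the molecule, but how much of it rests on the five-carbon chain rather than on the carbonyl itself cannot be read from these data. Compound 4 is therefore expected to fall somewhat above compound 1, a step of an 8.6-fold higher number from compound 1 to compound 4 (0.93 log units; beyond the scatter), with wide uncertainty. Compound 4 is estimated at 600 nM, in the range 100 nM to 4000 nM.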

Compound 4, half-maximal inhibitory concentration: 79 nM
Compound 4: the middle estimate sits 7.6-fold (0.88 log units) above what was measured, outside the stated range (below it).
By their numbers in this assay, from the lowest: compounds 1 and 4 (each within the scatter of the next); then compounds 2 and 3 (each within the scatter of the next).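

Replacing the group on the carbonyl carbon leaves the number in this assay effectively unchanged (a 1.1-fold higher number from compound 1 to compound 4 (0.05 log units; within the scatter)), so at this position the pent-1-en-1-yl chain is not needed to keep the read-out at the level of compound 1. The earlier compounds shown here gave no reading of this group, and this pair now shows that methyl, with a single carbon and no double bond, cannot be told apart from the longer unsaturated chain in this cell test. No independent measurement is available that would explain this result.

The compounds shown leave open how far the position tolerates groups of another kind on the carbonyl carbon, such as an amine, a carboxylic acid or a phenyl ring, and whether a saturated pentyl chain or a shorter ethyl or propyl chain would read the same. Going by these compounds alone, they also leave open what happens if the acetyl group of compound 4 is replaced by hydrogen while the rest of that molecule stays as it is, the one change that would isolate the part played by the carbonyl itself.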